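A Methyl on the Phenyl Ring: Compound 4 Expected

This account rests on a few compounds, and the source may have more. Where it says the series, first, only, none or still open, it means among the compounds named here.

Compound 1 `CCc1cc2ccccc2nc1-c1cc(-c2ccccc2)no1` has been measured in a functional assay on PC-3 cells (Homo sapiens) for inhibition, read by MTT assay, with a stated time of 24 h (on this read-out lower numbers stand for stronger inhibition and higher numbers for weaker inhibition), where compound 1 gives > 100000 nM, a limit of the assay rather than a number. Compound 2 `CCCCc1cc2ccccc2nc1-c1cc(-c2ccccc2)no1` gives > 100000 nM, again only a limit. Compound 3 `CCCCCc1cc2ccccc2nc1-c1cc(-c2ccccc2)no1` gives > 100000 nM, also a limit. Because all three sit at the limit of > 100000 nM in this assay, at which 3 of the 3 values shown sit, the steps a step that the two limits leave unreadable from compound 1 to compound 2, a step that the two limits leave unreadable from compound 1 to compound 3 and a step that the two limits leave unreadable from compound 2 to compound 3 cannot be sized. Compound 4 `CCc1cc2ccccc2nc1-c1cc(-c2ccc(C)cc2)no1` differs from compound 1 by methyl in place of hydrogen on an aromatic carbon: phenyl becomes 4-methylphenyl. Within the data shown here, no measured step touches this ring, so nothing here shows how that change acts. Compound 4 is therefore expected to give about 150000 nM, between 40000 nM and 600000 nM, most likely again only a limit, an expected step that the limit leaves unreadable from compound 1 to compound 4 that stays within the scatter.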

Compound 4, half-maximal inhibitory concentration: > 100000 nM
Compound 4: no number, only a limit (the forecaster's own chance of this, stated with the estimate: 85%); the middle value is on the limit's open side.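

Compound 1 and compound 4 each give only a limit of the assay, not a number, and the step between them cannot be sized. The compounds shown leave open whether any change to the shared core gives a measurable value.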